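Moving the methoxy group of compound 3

A few compounds are considered here, and "the series" means these few. Any claim that something is new, unique, unknown or untested is made for them only; others in the source may bear on it.

In a functional assay on ECa-109 cells for inhibition, with ECa-109 cell line (Homo sapiens) as the target, read by sulforhodamine B assay (a higher number here means a weaker inhibitor, a lower number a stronger inhibitor), the measured values are:
- compound 1 `O=C1C(Nc2ccccc2)=CC(=O)c2c1nc1n2[C@H]2OC[C@@H](O)[C@H]2OC1` gives 3560 nM
- compound 2 `O=C1C(Nc2ccc(Br)cc2)=CC(=O)c2c1nc1n2[C@H]2OC[C@@H](O)[C@H]2OC1` gives 1980 nM
- compound 3 `COc1ccc(NC2=CC(=O)c3c(nc4n3[C@H]3OC[C@@H](O)[C@H]3OC4)C2=O)cc1` gives 3410 nM

Compound 3 at 3410 nM lies within the scatter of both other compounds, with a 1.0-fold lower number from compound 1 to compound 3 (0.02 log units; within the scatter) and a 1.7-fold higher number from compound 2 to compound 3 (0.24 log units; within the scatter) as the steps that connect it to them. Compound 4 `COc1cccc(NC2=CC(=O)c3c(nc4n3[C@H]3OC[C@@H](O)[C@H]3OC4)C2=O)c1` differs from it by 3-methoxyphenyl in place of 4-methoxyphenyl on an amine nitrogen. Among the compounds with values here, no measured step moves a group in this way. The closest evidence is those two exchanges on an aromatic carbon and a 1.8-fold lower number from compound 1 to compound 2 (0.25 log units; within the scatter) as the third, all within the scatter, so no step beyond the scatter is expected in this assay here. The estimated step is a 1.1-fold lower number from compound 3 to compound 4 (0.03 log units; within the scatter) and nothing larger. Compound 4 is expected at 3200 nM with an estimated range from 1600 nM to 6000 nM for this measurement.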

Compound 4, half-maximal inhibitory concentration: 3340 nM
Compound 4: the middle estimate sits 1.0-fold (0.02 log units) below what was measured, within the range that was stated.
By their numbers in this assay, from the lowest: compounds 2, 4, 3 and 1 (each within the scatter of the next).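

In this assay, within the data shown here, moving the methoxy group on the ring attached to the amine nitrogen gives a 1.0-fold lower number from compound 3 to compound 4 (0.01 log units; within the scatter), the only measured step that moves a group rather than exchanging one. The 3-methoxyphenyl group also stays close to the unsubstituted and bromo compounds, with a 1.1-fold lower number from compound 1 to compound 4 (0.03 log units; within the scatter) and a 1.7-fold higher number from compound 2 to compound 4 (0.23 log units; within the scatter). No supporting data bear on this result. Still open, going by these compounds, is whether any change at this amine nitrogen can produce a step beyond the scatter, for example a carboxylic acid or a dimethylamino group on the phenyl ring, or a benzyl group in place of the phenyl.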